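From 3-hydroxyphenyl to 4-methylphenyl near the assay limit

This account rests on a few compounds, and the source may have more. Where it says the series, first, only, none or still open, it means among the compounds named here.

In a functional assay on HL-60 cells (Homo sapiens) for cytotoxicity, read by MTT assay, with a stated time of 48 h (a higher number here means a weaker inhibitor, a lower number a stronger inhibitor), compound 1 (`Fc1cccc(-c2nc(Nc3ccccc3)c3cc(F)ccc3n2)c1`) gives 48300 nM. Compound 2 (`Fc1cccc(-c2nc(Nc3cccc(Cl)c3)c3cc(F)ccc3n2)c1`) reads > 50000 nM, which is a limit of the assay and not a number. Compound 3 (`Oc1cccc(Nc2nc(-c3cccc(F)c3)nc3ccc(F)cc23)c1`) reads > 50000 nM, again only a limit. It therefore stands at the limit of > 50000 nM in this assay, at which 2 of the 3 values shown sit.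

Compound 4 (`Cc1ccc(Nc2nc(-c3cccc(F)c3)nc3ccc(F)cc23)cc1`) has 4-methylphenyl in place of 3-hydroxyphenyl on a nitrogen on an aromatic ring.

Within the data shown here, two measured steps bear on this change: an at least 1.0-fold higher number from compound 1 to compound 2 (0.01 log units; that floor lies within the scatter) and an at least 1.0-fold higher number from compound 1 to compound 3 (0.01 log units; that floor lies within the scatter). Both are floors within the scatter, so no large gain in strength is expected.

The expected step is an at least 1.1-fold lower number from compound 3 to compound 4 (0.04 log units; that floor lies within the scatter), with no shift beyond the scatter anticipated. For compound 4 the estimated value is 45000 nM, with an expected range of 20000 nM to 80000 nM.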

Compound 4, half-maximal inhibitory concentration: > 50000 nM
Compound 4 was reported as a limit (the forecaster's own chance of this, stated with the estimate: 55%); middle value at least 1.1-fold (0.04 log units) from the limit.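

In this assay, compound 4 is also reported only as a limit, so 4-methylphenyl in place of 3-hydroxyphenyl gives no readable gain. Among these compounds, the steps to compound 4 from compound 2 and from compound 3 cannot be read, and the one readable step is an at least 1.0-fold higher number from compound 1 to compound 4 (0.01 log units; that floor lies within the scatter). On this nitrogen, 3-chlorophenyl, 3-hydroxyphenyl and 4-methylphenyl now all end at the same limit: the limit of > 50000 nM in this assay, at which 3 of the 4 values shown sit.

Going by these compounds, whether an aminophenyl or a carboxyphenyl group here would give a reading under the limit stays open. On these data alone, how far apart compound 2, compound 3 and compound 4 truly lie also stays open.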